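The source may report more compounds than this note shows. Statements on the series, on what has been measured and on what is new or still open speak of the compounds shown alone.

Measured so far:
compound 1 `Cc1ccccc1-c1c(C)nn(-c2nc(-c3ccc(Cl)c(Cl)c3)c(SC(C)C)s2)c1C(=O)O` — 5500 nM
compound 2 `Cc1c(-c2cc(Cl)cc(Cl)c2)c(C(=O)O)nn1-c1nc(-c2ccncc2)c(SC(C)C)s1` — "not active" (no number reported)

In a functional assay on BJAB cells (Homo sapiens) for antiproliferative activity, with a stated time of 4 days (on this read-out lower numbers stand for an effect already at smaller amounts and higher numbers for an effect only at larger amounts of compound), compound 1 gives 5500 nM. Among the compounds with values here, compound 2 is recorded in this assay as "not active" (no number reported), with no number behind it, so compound 1 carries the only number among the two measured compounds and stands alone as the reference point. Compound 3 `COc1cc(C#N)cc(-c2c(C)nn(-c3nc(-c4ccc(Cl)c(Cl)c4)c(SC(C)C)s3)c2C(=O)O)c1` has not yet been tested in this assay. It differs from compound 1 in one place: 3-cyano-5-methoxyphenyl in place of 2-methylphenyl on an aromatic carbon. Within the data shown here, no pair of measured compounds that differ in a single place exists here, so nothing shows how a change on this aromatic carbon of the shared core moves the read-out. The expectation is therefore cautious: the step of a 1.2-fold lower number from compound 1 to compound 3 (0.09 log units; within the scatter) is expected to be small, in no clear direction, and not beyond the usual scatter. Compound 3 is accordingly estimated at 4500 nM, with a range from 1200 nM to 18000 nM.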

Compound 3, half-maximal effective concentration: 5200 nM
Compound 3: middle estimate off by 1.2-fold (0.06 log units), on the low side; the range from low to high includes it.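

In this assay, within the data shown here, placing 3-cyano-5-methoxyphenyl instead of 2-methylphenyl on this aromatic carbon of the shared core gives a 1.1-fold lower number from compound 1 to compound 3 (0.02 log units; within the scatter), the only measured step at this position so far. The read-out therefore stays within the usual scatter even though the entering group has 10 heavy atoms against 7 and brings 2 hydrogen-bond acceptors where the leaving group has 0. No separate measurement offers a reason for this result.

From the compounds shown here alone, the nitrile and the methoxy group enter together, so what each would do alone remains open. Also open, going by these compounds, is whether this position would tolerate something other than a substituted phenyl ring, such as a simple amine or a morpholine ring.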